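Sulfonyl ureas on HT-29 cells: chloropropyl versus ethyl

The source may report more compounds than this note shows. Statements on the series, on what has been measured and on what is new or still open speak of the compounds shown alone.

Of the compounds shown here, three of this small series have been measured. Compound 1 `Cc1ccccc1OS(=O)(=O)c1cccc(NC(=O)NCCCCl)c1` carries a 3-chloropropyl urea on a sulfonate ester core; compound 2 `Cc1ccccc1NS(=O)(=O)c1ccc(NC(=O)NCCCCl)cc1` carries the same urea on a sulfonamide core; compound 3 `CCNC(=O)Nc1cccc(S(=O)(=O)Oc2ccccc2C)c1` is the ethyl urea partner of compound 1. In a functional assay on HT-29 cells (Homo sapiens) for cytotoxicity, read by sulforhodamine B assay, with a stated time of 48 h (on this read-out lower numbers stand for stronger inhibition and higher numbers for weaker inhibition), compound 1 gives 21000 nM, compound 3 gives 44000 nM, and compound 2 gives 64000 nM. The difference between the core of compound 1 and the core of compound 2 is not broken down here.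

Among the compounds with values here, the one single-point change that has been measured is hydrogen in place of chloromethyl on a saturated chain carbon, two bonds along the chain from an amide-type nitrogen, and it gave a 2.1-fold higher number from compound 1 to compound 3 (0.32 log units; beyond the scatter). The values of compound 2 and compound 3 lie within the scatter of each other, so nothing is read from that pair.

Compound 4 `CCNC(=O)Nc1ccc(S(=O)(=O)Nc2ccccc2C)cc1` is the unmeasured ethyl urea partner of compound 2. The change from compound 2 to compound 4 is hydrogen in place of chloromethyl on a saturated chain carbon, two bonds along the chain from an amide-type nitrogen, and since the place is the same as before, this is the same change that led from compound 1 to compound 3. Within the data shown here, with only that one earlier step to rest on, the step from compound 2 to compound 4 is expected to be about a 2.0-fold higher number from compound 2 to compound 4 (0.31 log units; beyond the scatter), because compound 1 to compound 3 showed a 2.1-fold higher number from compound 1 to compound 3 (0.32 log units; beyond the scatter). Compound 4 is therefore estimated at 130000 nM in this assay, with a range from 50000 nM to 350000 nM given that the earlier step was only modest and measured once.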

Compound 4, half-maximal inhibitory concentration: > 200000 nM
Compound 4: a limit, no number (the forecaster's own chance of this, stated with the estimate: 25%); at least 1.5-fold (0.18 log units) between middle value and limit.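

In this assay, compound 4 gives > 200000 nM, which is a limit of the assay and not a number. Hydrogen in place of chloromethyl, which turns the 3-chloropropyl urea into the ethyl urea, still gives an at least 3.1-fold higher number from compound 2 to compound 4 (0.49 log units; beyond the scatter), so on the two cores shown the change moves the number the same way, with no compound going against this. The size of the step on the core of compound 2 stays unfixed, so these notes show only a shared direction and not a shared size, and they support no claim that the change acts more strongly on one core than on the other: the same change on two cores in this assay, a 2.1-fold higher number (0.32 log units; beyond the scatter) from compound 1 to compound 3 and an at least 3.1-fold higher number (0.49 log units; beyond the scatter) from compound 2 to compound 4; the limit leaves it open whether they differ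

Chlorine and one chain carbon leave together in both steps, so it remains open which of the two carries the change; a plain propyl urea, a 3-aminopropyl urea or a longer chain ending in chlorine would begin to separate them. The cores of compound 1 and compound 2 also differ in more than one place, which leaves open what each part of that difference contributes with the urea held fixed.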